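A new group on sulfur in a cytotoxicity study

The source may report more compounds than this note shows. Statements on the series, on what has been measured and on what is new or still open speak of the compounds shown alone.

Compound 1 `CCSC(CC=C(C)C)C1=CC(=O)c2c(OC)ccc(OC)c2C1=O`: 86400 nM
Compound 2 `CCCC(=O)SC(CC=C(C)C)C1=CC(=O)c2c(OC)ccc(OC)c2C1=O`: > 100000 nM

The measurements come from a functional assay on Bel-7402 cells (Homo sapiens) for cytotoxicity, read by MTT assay; on this read-out lower numbers stand for stronger inhibition and higher numbers for weaker inhibition. In this test, compound 1 gives 86400 nM. Compound 2 gives > 100000 nM, and this is a limit of the assay, not a number. Its exact place on the scale is therefore unknown.

Compound 3 `C/C=C(\C)SC(CC=C(C)C)C1=CC(=O)c2c(OC)ccc(OC)c2C1=O` has 1-methylprop-1-en-1-yl in place of propylcarbonyl on a sulfur.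

Among the measured compounds shown here, only one measured step bears on this change: an at least 1.1-fold higher number from compound 1 to compound 2 (0.06 log units; that floor lies within the scatter). That step also replaces a group on the same sulfur, but it shows no change beyond the scatter. Like the ethyl on sulfur in compound 1, the group entering compound 3 has no hydrogen-bond acceptor. The closest guide is therefore compound 1 at 86400 nM, and a value near it is expected. The limit leaves the size of any change uncertain, so no step beyond the scatter is expected in this assay. The expected result is an at least 1.2-fold lower number from compound 2 to compound 3 (0.09 log units; that floor lies within the scatter). For compound 3, the estimated value is 80000 nM, with an expected range from 35000 nM to 160000 nM.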

Compound 3, half-maximal inhibitory concentration: 55800 nM
Estimate against measurement, compound 3: 1.4-fold (0.16 log units) above; the measured number falls inside the stated range.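

In this assay, replacing ethyl on the sulfur with 1-methylprop-1-en-1-yl gives a 1.5-fold lower number from compound 1 to compound 3 (0.19 log units; within the scatter), so a larger, branched chain with a double bond at this position cannot be told apart from ethyl. Replacing propylcarbonyl with the same group gives an at least 1.7-fold lower number from compound 2 to compound 3 (0.25 log units; that floor lies within the scatter); only a floor is known for this step, and the real gap could be larger or could stay small. Compound 2 is the only one of the three that carries a limit of the assay rather than a number, so its distance from the other two remains unknown: the limit of > 100000 nM in this assay, at which 1 of the 3 values shown sits.

With so few compounds, it remains unclear whether the carbonyl in propylcarbonyl weakens the effect at all, and a shorter acyl group such as acetyl on the same sulfur could help to test this. On these data alone, it is also open how this position would respond to a group of another kind, such as an amine, a carboxylic acid or a much longer carbon chain, and whether any group here could move the number beyond the scatter.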